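Dropping One Methoxy from Compound 2

The source may report more compounds than this note shows. Statements on the series, on what has been measured and on what is new or still open speak of the compounds shown alone.

Measured so far:
compound 1 `C1=C(CCN2CCN(c3cccc4c3OCCO4)CC2)c2ccccc2CC1` — 229 nM
compound 2 `COc1cc2c(cc1OC)C(CCN1CCN(c3cccc4c3OCCO4)CC1)C2` — 794 nM

Within the data shown here, in an assay on isolated protein for binding affinity to 5-hydroxytryptamine receptor 1B (Rattus norvegicus) (on this read-out higher numbers stand for weaker inhibition and lower numbers for stronger inhibition), compound 2 gives 794 nM, the highest of the two numbers; compound 1 gives 229 nM, a lower number, but the two cores differ in more than one place and no single step connects them. Compound 3 `COc1ccc2c(c1)C(CCN1CCN(c3cccc4c3OCCO4)CC1)C2` is not yet measured. Its change from compound 2: hydrogen in place of methoxy on an aromatic carbon. Among the measured compounds shown here, no measured step of this kind exists, so the expected step of a 1.6-fold lower number from compound 2 to compound 3 (0.20 log units; within the scatter) is a modest one toward lower numbers, close to the scatter. Compound 3 is estimated at 500 nM, within 150 nM to 1600 nM.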

Compound 3, inhibition constant: 316 nM
Estimate against measurement, compound 3: 1.6-fold (0.20 log units) above, and the stated range covers the measured number.
By their numbers in this assay, from the lowest: compounds 1 and 3 (each within the scatter of the next); then compound 2.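

In this assay, among these compounds, hydrogen in place of methoxy on an aromatic carbon gives a 2.5-fold lower number from compound 2 to compound 3 (0.40 log units; beyond the scatter) as the only single-place step. Binding in this assay therefore does not depend on this methoxy, and its loss is tolerated with a gain beyond the scatter. Compound 3 keeps the other methoxy, so the step speaks for this one position only. No measured property is available to account for the step.

Open, on these data alone, is whether a fluorine, a hydroxyl or an amine at this aromatic carbon would shift the number further. Also open, as far as these compounds go, is whether the same step would hold on the core of compound 1.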